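Urea ring swap on a TRPV1 antagonist scaffold

The source may report more compounds than this note shows. Statements on the series, on what has been measured and on what is new or still open speak of the compounds shown alone.

Measured compounds:
- compound 1 `CC1CCN(c2nc(C(F)(F)F)ccc2CNC(=O)Nc2ccc3ccccc3n2)CC1`: "not active" (no number reported)
- compound 2 `CC1CCN(c2nc(C(F)(F)F)ccc2CNC(=O)Nc2cnc3ccccc3c2)CC1`: 9.5 nM
- compound 3 `CC1CCN(c2nc(C(F)(F)F)ccc2CNC(=O)Nc2cccc3cccnc23)CC1`: 91.6 nM

In an assay on isolated protein for antagonist activity at transient receptor potential cation channel subfamily V member 1 (Homo sapiens), read by FLIPR (on this read-out higher numbers stand for weaker inhibition and lower numbers for stronger inhibition), compound 2 gives 9.5 nM, the lowest of the two reported numbers. Its nearest neighbour, compound 3, gives 91.6 nM, and compound 1 is reported as not active, with no number. Among the compounds with values here, the only step that can be traced in one place is a 9.6-fold higher number from compound 2 to compound 3 (0.98 log units; beyond the scatter), where the bicyclic ring on the urea nitrogen keeps its atoms but changes its attachment. Compound 4 `CC1CCN(c2nc(C(F)(F)F)ccc2CNC(=O)Nc2nccc3cccnc23)CC1` is not yet measured; it differs from compound 2 by a group of 10 heavy atoms (8 carbon, 2 nitrogen; 2 six-membered aromatic rings with 1 hetero atom each) in place of a group of 10 heavy atoms (9 carbon, 1 nitrogen; one six-membered aromatic ring of carbon only, one six-membered aromatic ring with 1 hetero atom), on an amide-type nitrogen. Within the data shown here, both earlier comparisons point the same way: changing the bicyclic group away from that of compound 2 lost activity, modestly in compound 3 and entirely in compound 1. A weaker result is therefore expected for compound 4, with an expected step of about a 21-fold higher number from compound 2 to compound 4 (1.32 log units; beyond the scatter). It is also possible that compound 4 will end up as a limit only, as compound 1 did. The estimate for compound 4 is 200 nM, within 30 nM to 3000 nM.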

Compound 4, inhibition constant: "not active" (no number reported)
Nothing numeric was reported for compound 4; no gap can be computed for the estimate.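

Within the data shown here, compound 4, like compound 1, carries no number, so no step from compound 2 to compound 4 can be read. Nothing measured here explains the result. The compounds shown leave open what sets the quinolin-3-yl group apart from the other ring groups.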